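A few compounds are considered here, and "the series" means these few. Any claim that something is new, unique, unknown or untested is made for them only; others in the source may bear on it.

Compound 1 `CCCS(=O)(=O)Nc1cccc2c1CCC2c1ncc[nH]1` gives in a functional assay on CHO cells for agonist activity at Alpha-1D adrenergic receptor (Homo sapiens), read by FLIPR and calcium flux (a lower number here means that less compound is needed, a higher number that more compound is needed for the effect), only the assay limit > 10000 nM. Compound 2 `Cn1nccc1-c1cccc2c1CCC2c1ncc[nH]1` likewise gives only the limit > 10000 nM. Compound 3 `c1cncc(-c2cccc3c2CCC3c2ncc[nH]2)c1` also gives only the limit > 10000 nM.

All three values sit at the same limit (the limit of > 10000 nM in this assay, at which 3 of the 3 values shown sit), so compound 3 stands at the limit with no number to set it against compounds 1 and 2. The steps a step that the two limits leave unreadable from compound 1 to compound 2, a step that the two limits leave unreadable from compound 1 to compound 3 and a step that the two limits leave unreadable from compound 2 to compound 3 are all of unreadable size. Compound 4 `c1cc(-c2nccs2)c2c(c1)C(c1ncc[nH]1)CC2` differs from compound 3 by 1,3-thiazol-2-yl in place of pyridin-3-yl on an aromatic carbon. Within the data shown here, no measured step bearing on this change has a readable size; every aromatic replacement at this carbon so far has stayed at the limit. The expected step that the limit leaves unreadable from compound 3 to compound 4 is none beyond the scatter. Compound 4 is estimated at 20000 nM, range 5000 nM to 100000 nM, most likely again a limit.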

Compound 4, half-maximal effective concentration: 3190 nM
Estimate against measurement, compound 4: 6.3-fold (0.80 log units) above, and the stated range ends above it.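

In this assay this aromatic carbon now gives a readable response: 1,3-thiazol-2-yl in place of pyridin-3-yl is an at least 3.1-fold lower number from compound 3 to compound 4 (0.49 log units; beyond the scatter). The same group gives an at least 3.1-fold lower number from compound 2 to compound 4 (0.49 log units; beyond the scatter), and against (propylsulfonyl)amino it gives an at least 3.1-fold lower number from compound 1 to compound 4 (0.49 log units; beyond the scatter). Each step is only a bound, and the steps among compounds 1, 2 and 3 cannot be read: the limit of > 10000 nM in this assay, at which 3 of the 4 values shown sit.

Going by these compounds, it remains open whether the lower number follows the sulfur of the 1,3-thiazol-2-yl group or its five-membered aromatic ring. A 1,3-oxazol-2-yl group on the same carbon would separate the two.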